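Swapping an aryl amide for pyrimidine in a thiourea series

The compounds below may be only part of what the source reports. "The series", "measured", "known", "first", "only" and "open" are said of these compounds alone.

Measured so far:
- Compound 1, `NC(=O)c1c(NC(=O)c2ccccc2Cl)sc2c1CCN(C(=S)Nc1ccccc1-c1ccccc1)C2`: 25800 nM
- Compound 2, `NC(=O)c1c(NC(=O)c2ccccc2C(F)(F)F)sc2c1CCN(C(=S)Nc1ccccc1Cl)C2`: 21900 nM

Both compounds were tested in a functional assay on MKN-74 cells (Homo sapiens) for antiproliferative activity, with a stated time of 24 h; on this read-out higher numbers stand for weaker inhibition and lower numbers for stronger inhibition. In this assay compound 1 gives 25800 nM and compound 2 gives 21900 nM; these two numbers lie within the usual scatter of each other, so neither can be called more or less active than the other. Both sit at weak, micromolar-range inhibition.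

Compound 3, `NC(=O)c1c(NC(=O)c2ccncn2)sc2c1CCN(C(=S)Nc1ccccc1Cl)C2`, has not yet been measured. It differs from compound 2 in one place: pyrimidin-4-yl in place of 2-(trifluoromethyl)phenyl on a carbonyl carbon. The two compounds therefore share the same core, the same thiourea and the same 2-chlorophenyl group, and differ only in the ring attached to the amide carbonyl.

Among the compounds with values here, no step between measured compounds is available to calibrate this kind of change, so any expectation is uncertain. The two measured compounds differ in two places at once, and their numbers do not separate, which gives little guidance on how sensitive the read-out is to the amide substituent.

On that basis the change from compound 2 to compound 3 is expected to be modest, within or only slightly beyond the scatter, and without a firm direction. The step from compound 2 to compound 3 is estimated as a 1.4-fold higher number from compound 2 to compound 3 (0.14 log units; within the scatter). Compound 3 is therefore expected to give about 30000 nM, with a plausible range from 8000 nM to 120000 nM.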

Compound 3, half-maximal inhibitory concentration: 28400 nM
The estimate for compound 3 lay 1.1-fold (0.02 log units) above the measured number; the measured number falls inside the stated range.
By their numbers in this assay, from the lowest: compounds 2, 1 and 3 (each within the scatter of the next).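

Within the data shown here, this is the first comparison here in which only one place changes, the ring on a carbonyl carbon whose other neighbour is an amide-type nitrogen. In this assay the step is a 1.3-fold higher number from compound 2 to compound 3 (0.11 log units; within the scatter) and so does not separate the two compounds. At this position, then, 2-(trifluoromethyl)phenyl, a carbon-only aromatic ring with no hydrogen-bond acceptors, and pyrimidin-4-yl, a ring with two nitrogen atoms and two hydrogen-bond acceptors, give numbers that cannot be told apart, and no measured evidence is available to explain this.

From the compounds shown here alone, two rings say little about the full range of groups this position might accept, so it remains open whether a morpholine ring or a carboxylic acid in the same place would move the number beyond the scatter, in either direction. Going by these compounds, it also remains open whether the same swap of rings would give a similar result with a group other than 2-chlorophenyl on the thiourea.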